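Shortening a Propyl Chain on a Shared Core

This account rests on a few compounds, and the source may have more. Where it says the series, first, only, none or still open, it means among the compounds named here.

Measured compounds:
compound 1, `Cc1nc(-c2cnc3ccc(-c4ccc(N)cc4)cc3c2)no1`: > 2500 nM
compound 2, `CCCc1ccc(-c2ccc3ncc(-c4noc(C)n4)cc3c2)cc1`: > 7400 nM

Both compounds were tested in a functional assay on RD cells (Homo sapiens) for inhibition, read by luminescence and ATP content, with a stated time of 72 h; a lower number here means that less compound is tolerated, a higher number that more compound is tolerated. For compound 1 the result is only a limit of the assay, > 2500 nM. For compound 2 the result is also a limit of the assay, > 7400 nM. Among the measured compounds shown here, the only measured step, a step that the two limits leave unreadable from compound 1 to compound 2, is therefore unreadable; both of its ends sit at limits, as the limit of > 2500 nM in this assay, at which 1 of the 2 values shown sits, and the limit of > 7400 nM in this assay, at which 1 of the 2 values shown sits, show. Compound 2 thus stands on a limit, not on a number.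

Compound 3, `CCc1ccc(-c2ccc3ncc(-c4noc(C)n4)cc3c2)cc1`, differs from compound 2 by hydrogen in place of methyl on a saturated chain carbon, two bonds along the chain from an aromatic carbon. For the measured compounds named here, no measured step bears on this change with a readable size, as the single step between the measured compounds is unreadable. The step that the limit leaves unreadable from compound 2 to compound 3 is expected to be none beyond the scatter, most likely ending again at a limit. Compound 3 is therefore estimated at 8000 nM, within 3000 nM to 25000 nM.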

Compound 3, half-maximal cytotoxic concentration: > 7400 nM
Compound 3: only a limit was reported; the forecaster's own chance of this, stated with the estimate: 75%; the middle value lies beyond the limit too.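

In this assay compound 3 gives > 7400 nM as a limit of the assay, not a number. Among the compounds shown here, no step among compound 1, compound 2 and compound 3 can be read. The compounds shown leave open whether propyl to ethyl changes the half-maximal cytotoxic concentration at all, and at what concentration any of the three would reach it.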